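Swapping an Acid for a Cyclopropyl Amide

A few compounds are considered here, and "the series" means these few. Any claim that something is new, unique, unknown or untested is made for them only; others in the source may bear on it.

Compound 1 `O=C(O)c1ccc(NCc2cccc(Oc3ccccc3)c2)cc1` carries a carboxy group on its outer ring. In a functional assay on CHO cells for agonist activity at Free fatty acid receptor 1 (Homo sapiens) (on this read-out higher numbers stand for an effect only at larger amounts of compound and lower numbers for an effect already at smaller amounts), compound 1 gives < 10000 nM, which is a limit of the assay rather than a number (the limit of < 10000 nM in this assay, at which 1 of the 2 values shown sits). Compound 2 `Cc1nc(-c2ccc(C(F)(F)F)cc2)sc1CNc1ccc(CCC(N)=O)cc1` is built on a different frame, and in this assay compound 2 gives 12.9 nM. Compound 3 `CC(C)NC(=O)[C@H]1C[C@@H]1c1ccc(NCc2cccc(Oc3ccccc3)c2)cc1` differs from compound 1 by 2-(isopropylcarbamoyl)cyclopropyl in place of carboxy on an aromatic carbon. For the measured compounds named here, no measured pair shows this change, so its direction is open. The expected step that the limit leaves unreadable from compound 1 to compound 3 points toward an effect at smaller amounts. Compound 3 is estimated at 500 nM, within 50 nM to 5000 nM.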

Compound 3, half-maximal effective concentration: 12.6 nM
Compound 3: the middle estimate sits 40-fold (1.60 log units) above what was measured; measured number outside the range, below it.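

No step from compound 1 to compound 3 can be read, because the value of compound 1 is a limit and not a number: the limit of < 10000 nM in this assay, at which 1 of the 3 values shown sits.

The compounds shown leave open how much replacing carboxy with 2-(isopropylcarbamoyl)cyclopropyl changes the effect.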